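The compounds below may be only part of what the source reports. "The series", "measured", "known", "first", "only" and "open" are said of these compounds alone.

Measured compounds:
Compound 1 `O=c1c(CSc2cc(=O)c3ccccc3s2)coc2ccccc12` gives 2600 nM in a functional assay on HeLa cells (Homo sapiens) for cytotoxicity, read by MTT assay, with a stated time of 72 h; on this read-out lower numbers stand for stronger inhibition and higher numbers for weaker inhibition.
Compound 2 `Cc1ccc2oc(CSc3nc4nc(C)cc(C)n4n3)cc(=O)c2c1` gives > 25000 nM in this assay.

Compound 2 stands at the edge of what this assay reports: its value is a limit of the assay, not a number, (the limit of > 25000 nM in this assay, at which 1 of the 2 values shown sits). Compound 3 `Cc1cc(C)n2nc(SCc3cc(=O)c4ccccc4o3)nc2n1` differs from compound 2 by hydrogen in place of methyl on an aromatic carbon. Going by the values given here, no measured pair shows this change on its own; compound 1 also carries a different sulfur-linked heterocycle, so the two values shown say nothing about the methyl by itself. With compound 2 sitting at the limit (the limit of > 25000 nM in this assay, at which 1 of the 2 values shown sits), a change this small is expected to leave the read-out within the usual scatter, with no direction favoured. Compound 3 is therefore expected at 30000 nM, within a range from 10000 nM to 100000 nM. The step that the limit leaves unreadable from compound 2 to compound 3 that this estimate implies is expected to stay within the scatter, and most likely only a limit will again be reported.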

Compound 3, half-maximal inhibitory concentration: > 25000 nM
Compound 3 was reported as a limit (the forecaster's own chance of this, stated with the estimate: 70%); the middle value lies beyond the limit too.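

No step can be read from compound 2 to compound 3, because in this assay both stand at a limit of the assay, not at a number: the limit of > 25000 nM in this assay, at which 2 of the 3 values shown sit. The compounds shown leave open what hydrogen in place of methyl on an aromatic carbon does to this read-out.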